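Swapping the sulfonamide aryl group: from naphthyl back to a single ring

The source may hold more compounds than are shown below. What is called first, only, known or untested is meant among the compounds shown, and "the series" means these compounds.

Compound 2 `CN(c1cccc2ccccc12)S(=O)(=O)C1CC2OC1C(c1ccc(NC(=O)CCCCCCC(=O)O)cc1)=C2c1ccc(O)cc1` carries a methyl(naphthalen-1-yl)amino group on the sulfonyl sulfur of the shared core. In a functional assay on DU-145 cells (Homo sapiens) for antiproliferative activity, read by MTT assay, with a stated time of 72 h (a higher number here means a weaker inhibitor, a lower number a stronger inhibitor), compound 2 gives 70900 nM. Within the data shown here, that is the only number recorded here, the one other entry being a limit. Compound 1 `Cc1cccc(N(C)S(=O)(=O)C2CC3OC2C(c2ccc(NC(=O)CCCCCCC(=O)O)cc2)=C3c2ccc(O)cc2)c1` bears 3-methylphenyl on the sulfonamide nitrogen instead, and in this assay compound 1 reaches only the limit > 100000 nM (the limit of > 100000 nM in this assay, at which 1 of the 2 values shown sits). Among the measured compounds shown here, the one measured step, an at least 1.4-fold lower number from compound 1 to compound 2 (0.14 log units; that floor lies within the scatter), sits within the scatter at its floor, so it says little about direction.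

Compound 3 `CCN(c1cccc(OC)c1)S(=O)(=O)C1CC2OC1C(c1ccc(NC(=O)CCCCCCC(=O)O)cc1)=C2c1ccc(O)cc1` differs from compound 2 in one place: ethyl(3-methoxyphenyl)amino in place of methyl(naphthalen-1-yl)amino on a sulfonyl sulfur. This change undoes the two-ring aryl that distinguishes compound 2 from compound 1 and returns to a single six-membered aromatic ring, now bearing methoxy, with ethyl rather than methyl on nitrogen. Because compound 1 with a single-ring aryl stays at the limit (the limit of > 100000 nM in this assay, at which 1 of the 2 values shown sits), compound 3 is expected to move back toward that limit, a step of a 1.7-fold higher number from compound 2 to compound 3 (0.23 log units; within the scatter), with the figure possibly again reported only as a limit. Compound 3 is therefore estimated at 120000 nM, in the range 45000 nM to 320000 nM.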

Compound 3, half-maximal inhibitory concentration: 71100 nM
The estimate for compound 3 lay 1.7-fold (0.23 log units) above the measured number, and the stated range covers the measured number.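

In this assay, a measured number does not depend on the two-ring naphthalen-1-yl group: ethyl(3-methoxyphenyl)amino, with one six-membered aromatic ring of carbon only, gives a 1.0-fold higher number from compound 2 to compound 3 (0.00 log units; within the scatter), so the two groups cannot be told apart at this position on the sulfonyl sulfur. Against the other single-ring group, the reading is an at least 1.4-fold lower number from compound 1 to compound 3 (0.14 log units; that floor lies within the scatter), and with that floor inside the scatter, this comparison gives no direction, just as the comparison of compound 1 with compound 2 gave none. Compound 1 remains the one compound recorded only as a limit, not as a number: the limit of > 100000 nM in this assay, at which 1 of the 3 values shown sits.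

The compounds shown do not separate the parts of this change, since ethyl on nitrogen, the methoxy group and the loss of the second ring arrive together in compound 3. They also leave open whether a piperidine on the sulfonyl sulfur, or a hydroxy or amino group in place of the methoxy group on the ring, would shift the number beyond the scatter.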